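The compounds below may be only part of what the source reports. "The series", "measured", "known", "first", "only" and "open" are said of these compounds alone.

Measured so far in a functional assay (Mus musculus) for inhibition, with a stated time of 5 days; on this read-out lower numbers stand for stronger inhibition and higher numbers for weaker inhibition:
- compound 1 `O=Cc1cn(-c2ccc(O)cc2)nc1-c1cccc(O)c1`: 42000 nM
- compound 2 `O=C(O)/C=C/c1cn(-c2ccc(O)cc2)nc1-c1cc(O)ccc1O`: > 100000 nM, a limit
- compound 3 `O=C(O)/C=C/c1cn(-c2ccc(O)cc2)nc1-c1ccccc1`: > 100000 nM, a limit

Compound 2 has no number, only a limit: the limit of > 100000 nM in this assay, at which 2 of the 3 values shown sit.

Compound 4 `O=Cc1cn(-c2ccc(O)cc2)nc1-c1cc(O)ccc1O` has formyl in place of 2-carboxyethenyl on an aromatic carbon.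

Within the data shown here, the one measured step, a step that the two limits leave unreadable from compound 2 to compound 3, involves another change and gives no size. The nearest guide is compound 1, which also carries formyl and gives a real number, 42000 nM, although its hydroxyphenyl group differs.

In this assay, a shift toward stronger inhibition is therefore expected, of uncertain size: an at least 3.3-fold lower number from compound 2 to compound 4 (0.52 log units; beyond the scatter). Compound 4 is estimated at 30000 nM, within 8000 nM to 100000 nM.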

Compound 4, half-maximal inhibitory concentration: 43000 nM
The estimate for compound 4 lay 1.4-fold (0.16 log units) below the measured number; measured number inside the range.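

In this assay, formyl on this aromatic carbon gives a measurable number where 2-carboxyethenyl does not, with an at least 2.3-fold lower number from compound 2 to compound 4 (0.36 log units; beyond the scatter). Compound 2 has only a limit, so this step has no upper size: the limit of > 100000 nM in this assay, at which 2 of the 4 values shown sit.

With formyl present, hydroxy in place of hydrogen on an aromatic carbon leaves the values level, with a 1.0-fold higher number from compound 1 to compound 4 (0.01 log units; within the scatter). The compounds shown do not separate the carboxylic acid of 2-carboxyethenyl from its double bond, as both leave together. On these data alone, how an aminomethyl group or a primary amide would read at this aromatic carbon remains open.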